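Sulfur-Bearing Side Chains on a Shared Core in Rats

The source may report more compounds than this note shows. Statements on the series, on what has been measured and on what is new or still open speak of the compounds shown alone.

Compound 1 `CCn1c(=N)sc2cc(OC(F)(F)F)ccc21` gives 5 mg/kg in a functional assay on the whole organism with Rattus norvegicus as the target; on this read-out lower numbers stand for an effect already at smaller amounts and higher numbers for an effect only at larger amounts of compound.
Compound 2 `N=c1sc2cc(OC(F)(F)F)ccc2n1CCS(=O)(=O)O` reaches only a limit of the assay, > 10 mg/kg.
Compound 3 `CCCSCCn1c(=N)sc2cc(OC(F)(F)F)ccc21` gives 2.4 mg/kg.

Compound 3 holds the lowest of the two numbers; the nearest is compound 1, with a 2.1-fold lower number from compound 1 to compound 3 (0.32 log units; beyond the scatter). For compound 2 the value is a limit, (the limit of > 10 mg/kg in this assay, at which 1 of the 3 values shown sits). Compound 4 `CC[S+]([O-])CCn1c(=N)sc2cc(OC(F)(F)F)ccc21` differs from compound 3 by a group of 4 heavy atoms (2 carbon, 1 oxygen, 1 sulfur; no ring) in place of a group of 4 heavy atoms (3 carbon, 1 sulfur; no ring), on a saturated chain carbon, two bonds along the chain from an aromatic nitrogen. For the measured compounds named here, two measured steps touch the same spot: a 2.1-fold lower number from compound 1 to compound 3 (0.32 log units; beyond the scatter) and an at least 4.1-fold lower number from compound 2 to compound 3 (0.61 log units; beyond the scatter). Going by the values given here, both gains came with propylsulfanyl entering, and the group entering compound 4 has no measured counterpart, so a modest step back toward the number of compound 1 is expected, a 1.7-fold higher number from compound 3 to compound 4 (0.22 log units; within the scatter). Compound 4 is estimated to give 4 mg/kg, expected between 1.5 mg/kg and 10 mg/kg.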

Compound 4, dose for half-maximal effect: 1.2 mg/kg
Compound 4: middle estimate off by 3.3-fold (0.52 log units), on the high side; measured number outside the range, below it.
By their numbers in this assay, from the lowest: compounds 4 and 3 (each within the scatter of the next); then compound 1. At a limit, above all of these: compound 2.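

For the compounds shown here, the group entering in compound 4 also improves on hydrogen at this place (a 4.2-fold lower number from compound 1 to compound 4 (0.62 log units; beyond the scatter)), so propylsulfanyl is not the only sulfur-bearing group with a gain, and its exchange for propylsulfanyl stays within the scatter (a 2.0-fold lower number from compound 3 to compound 4 (0.30 log units; within the scatter)). In place of sulfo the step is larger (an at least 8.3-fold lower number from compound 2 to compound 4 (0.92 log units; beyond the scatter)). That step rests on a limit of the assay for compound 2: (the limit of > 10 mg/kg in this assay, at which 1 of the 4 values shown sits).

Compound 4 differs from compound 3 by both one carbon fewer and an added oxygen, and these two changes are not separated here. From the compounds shown here alone, how an amine, a carboxylic acid or a longer chain would behave at this place stays open.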